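Swapping pyridin-2-yl for phenyl on the ketone of compound 3

This account rests on a few compounds, and the source may have more. Where it says the series, first, only, none or still open, it means among the compounds named here.

In a functional assay on Huh-7 cells (Homo sapiens) for inhibition, read by sulforhodamine B assay, with a stated time of 72 h (on this read-out lower numbers stand for stronger inhibition and higher numbers for weaker inhibition), compound 3 `O=C(/C=C/c1cn(-c2ccccc2)nc1-c1cccnc1)c1ccccn1` gives 6400 nM, the highest of the three numbers recorded. Among the compounds with values here, compound 1 `COc1ccc(C(=O)/C=C/c2cn(-c3ccccc3)nc2-c2ccsc2)cc1OC` gives 2900 nM and compound 2 `COc1ccc(C(=O)/C=C/c2cn(-c3ccccc3)nc2-c2ccsc2)c(OC)c1` gives 3000 nM, both lower than compound 3 by more than the scatter, while the one directly comparable pair, a 1.0-fold higher number from compound 1 to compound 2 (0.01 log units; within the scatter), shows nothing beyond the scatter for moving the methoxy groups around the aryl ketone.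

Compound 4 `O=C(/C=C/c1cn(-c2ccccc2)nc1-c1cccnc1)c1ccccc1` differs from compound 3 by phenyl in place of pyridin-2-yl on a carbonyl carbon. Within the data shown here, no measured pair tests this exchange: compounds 1 and 2 carry substituted phenyl ketones but also a different group on the shared core, so their values cannot be read as a step from compound 3. Among the measured compounds shown here, the only measured step, a 1.0-fold higher number from compound 1 to compound 2 (0.01 log units; within the scatter), concerns a different change. The expectation therefore rests on the shared core alone, and a modest move toward a lower number, or none beyond the scatter, is expected, a 1.4-fold lower number from compound 3 to compound 4 (0.15 log units; within the scatter). Compound 4 is estimated at 4500 nM in this assay, with a range from 1500 nM to 13000 nM.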

Compound 4, half-maximal inhibitory concentration: 2300 nM
Compound 4: the middle estimate sits 2.0-fold (0.29 log units) above what was measured, and the stated range covers the measured number.
By their numbers in this assay, from the lowest: compounds 4, 1 and 2 (each within the scatter of the next); then compound 3.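

In this assay, the group on the carbonyl carbon proves able to move the number beyond the scatter: phenyl in place of pyridin-2-yl gives (a 2.8-fold lower number from compound 3 to compound 4 (0.44 log units; beyond the scatter)). Within the data shown here, the earlier pair, which only moved methoxy groups on the aryl ketone, gave no such shift (a 1.0-fold higher number from compound 1 to compound 2 (0.01 log units; within the scatter)), so this is the first sign that the choice between a ring of carbon only and a ring with one hetero atom matters at this place. The data offer no measurement that explains why the number falls with this exchange.

The compounds shown give only these two unsubstituted rings on this carbonyl carbon with this shared core, so a single step says nothing about how general the effect is. As far as these compounds go, whether an amine or a carboxylic acid on the benzoyl group would shift the number further remains open.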